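Chloro substitution on an aromatic ring in two related series

The source may report more compounds than this note shows. Statements on the series, on what has been measured and on what is new or still open speak of the compounds shown alone.

Compound 1 `O=C(/C(=C/c1ccccc1)CCl)c1ccccc1` and compound 2 `O=C(/C(=C/c1ccc(Cl)cc1)CCl)c1ccccc1` form one pair in a functional assay on HBL-100 cells (Homo sapiens) for inhibition, read by sulforhodamine B assay, with a stated time of 48 h; on this read-out lower numbers stand for stronger inhibition of growth and higher numbers for weaker inhibition of growth. In this assay compound 1 gives 12000 nM, and compound 2 gives 3200 nM. The change between them, (chloro in place of hydrogen on an aromatic carbon), produced a 3.8-fold lower number from compound 1 to compound 2 (0.57 log units; beyond the scatter). Compound 3 `CC(=O)OC/C(=C\C1CCCCC1)C(=O)c1ccccc1` belongs to a second core; the difference between the two cores is not broken down here. In this assay compound 3 gives 21000 nM, which is within the scatter of compound 1 but stands well apart from compound 2. Compound 4 `CC(=O)OC/C(=C\C1CCCCC1)C(=O)c1ccc(Cl)cc1` has not been measured. It is related to compound 3 by chloro in place of hydrogen on an aromatic carbon, and the place of the new group reads the same way in both pairs, so this is the same change as that from compound 1 to compound 2. Within the data shown here, the account expects that the step from compound 3 to compound 4 in this assay will resemble, though perhaps not fully match, the earlier one, since the only measured precedent is a 3.8-fold lower number from compound 1 to compound 2 (0.57 log units; beyond the scatter) on a different core. On that basis compound 4 is expected to give 7000 nM, with a plausible range from 3000 nM to 17000 nM, which corresponds to an estimated step of a 3.0-fold lower number from compound 3 to compound 4 (0.48 log units; beyond the scatter).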

Compound 4, concentration for 50% growth inhibition: 31000 nM
Compound 4: middle estimate off by 4.4-fold (0.65 log units), on the low side; measured number outside the range, above it.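

In this assay, the step on the second core is a 1.5-fold higher number from compound 3 to compound 4 (0.17 log units; within the scatter), so compound 3 and compound 4 cannot be told apart there. Chloro in place of hydrogen on an aromatic carbon therefore did not carry over from the core of compound 1 to the core of compound 3 with the size it had on the first core, and the two steps differ: the same change on two cores in this assay, a 3.8-fold lower number (0.57 log units; beyond the scatter) from compound 1 to compound 2 and a 1.5-fold higher number (0.17 log units; within the scatter) from compound 3 to compound 4, 5.5-fold (0.74 log units) apart, beyond the scatter of two such steps This shows that, among these compounds, the step on one core is a poor guide to the step on the other, but it does not show which feature of the cores separates the two results, as the cores differ in more than one place and each offers only a single pair.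

The compounds shown leave open how a bromo or a methoxy group would read in place of the chloro on either core. They also leave open whether a hydroxymethyl group in place of the acetoxymethyl chain would bring the step on the second core closer to that on the first.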